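Methyl in Place of Chloro on the Five-Membered Ring

The compounds below may be only part of what the source reports. "The series", "measured", "known", "first", "only" and "open" are said of these compounds alone.

Three compounds have been measured in an assay on cells for positive allosteric modulation of Cystic fibrosis transmembrane conductance regulator variant G551D (Homo sapiens), with stated times of 10 min and 2 min, in the presence of a further agent that is not named here; a higher number here means that more compound is needed for the effect, a lower number that less compound is needed:
compound 1, `CC1(C)Cc2c(sc(NC(=O)C3(CO)CC3)c2C(N)=O)C(C)(C)O1`: 1320 nM
compound 2, `CC1(C)Cc2c(sc(NC(=O)[C@@H](O)C(C)(C)C)c2C(N)=O)C(C)(C)O1`: 421 nM
compound 3, `CC1(C)Cc2c(sc(NC(=O)c3[nH]ncc3Cl)c2C(N)=O)C(C)(C)O1`: 81 nM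

All three share one core and differ only in the group on the carbonyl carbon of the amide. Compound 3 gives the lowest of the three numbers: the gap is a 5.2-fold lower number from compound 2 to compound 3 (0.72 log units; beyond the scatter) and a 16-fold lower number from compound 1 to compound 3 (1.21 log units; beyond the scatter), and between the two non-aromatic groups there is a 3.1-fold lower number from compound 1 to compound 2 (0.50 log units; beyond the scatter). Each of these steps exchanges the whole group on the carbonyl carbon.

Compound 4, `Cc1cn[nH]c1C(=O)Nc1sc2c(c1C(N)=O)CC(C)(C)OC2(C)C`, keeps the five-membered ring of compound 3 and changes (methyl in place of chloro on an aromatic carbon). Within the data shown here, no measured step keeps this ring and alters one substituent on it, so none of the three steps bears directly on this change. With nothing to point either way, the step in this assay is expected to stay within the usual scatter. The estimate for compound 4 in this assay is 100 nM, with a range from 40 nM to 250 nM. The expected step is a 1.2-fold higher number from compound 3 to compound 4 (0.09 log units; within the scatter).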

Compound 4, half-maximal effective concentration: 123 nM
Compound 4: middle estimate off by 1.2-fold (0.09 log units), on the low side; the range from low to high includes it.
By their numbers in this assay, from the lowest: compounds 3 and 4 (each within the scatter of the next); then compound 2; then compound 1.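

In this assay, chloro and methyl on this aromatic carbon, next to the ring atom that bears a large group, give values that lie within the scatter of each other (a 1.5-fold higher number from compound 3 to compound 4 (0.18 log units; within the scatter)). The pyrazole with methyl also stays clearly apart from the two non-aromatic groups (a 3.4-fold lower number from compound 2 to compound 4 (0.53 log units; beyond the scatter); an 11-fold lower number from compound 1 to compound 4 (1.03 log units; beyond the scatter)), so among these compounds that separation does not rest on chloro alone. Nothing measured here explains why the two substituents read alike.

The compounds shown leave open how an ethyl chain, a methoxy group or an amine on this carbon would read. They also leave open whether the ring with plain hydrogen at this place would stay at the level of compound 3 and compound 4.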